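The source may hold more compounds than are shown below. What is called first, only, known or untested is meant among the compounds shown, and "the series" means these compounds.

In a functional assay on HT-29 cells (Homo sapiens) (a higher number here means a weaker inhibitor of growth, a lower number a stronger inhibitor of growth), compound 2 `O=S(=O)(/C=C/c1ccc(Cl)cc1)Cc1ccc(Nc2ncnc3ccc(Br)cc23)cc1` gives only > 100000 nM, a limit of the assay and not a number. That reading is the limit of > 100000 nM in this assay, at which 1 of the 2 values shown sits. Compound 3 `O=S(=O)(/C=C/c1ccc(O)cc1)Cc1ccc(Nc2ncnc3ccc(Br)cc23)cc1` differs from compound 2 by one group, with hydroxy in place of chloro on an aromatic carbon. Compound 1 `O=S(=O)(/C=C/c1ccc(O)cc1)Cc1ccc(Nc2ncnc3ccccc23)cc1`, which also carries a 4-hydroxyphenyl group, gives 2000 nM in this assay, so a large change toward stronger inhibition of growth is expected. The expected change is an at least 16-fold lower number from compound 2 to compound 3 (1.22 log units; beyond the scatter). For compound 3 the estimated value is 6000 nM, with an expected range of 1200 nM to 40000 nM.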

Compound 3, concentration for 50% growth inhibition: 9000 nM
The estimate for compound 3 lay 1.5-fold (0.18 log units) below the measured number; the measured number falls inside the stated range.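

In this assay, hydroxy in place of chloro on the 4-phenyl ring of the bromo compounds brings measurable inhibition of growth, with an at least 11-fold lower number from compound 2 to compound 3 (1.04 log units; beyond the scatter) as the step. Compound 2 gives a limit and not a number, and the step is therefore only a bound: the limit of > 100000 nM in this assay, at which 1 of the 3 values shown sits. With the 4-hydroxyphenyl group held fixed, bromo in place of hydrogen on an aromatic carbon gives a 4.5-fold higher number from compound 1 to compound 3 (0.65 log units; beyond the scatter), so this change weakens inhibition only modestly.

As far as these compounds go, whether chloro would also read at the limit without the bromo stays open. So does whether a methoxy or an amine in place of hydroxy would keep the inhibition of growth.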